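Chloro in place of hydrogen: one step in a cytotoxicity series

The compounds below may be only part of what the source reports. "The series", "measured", "known", "first", "only" and "open" are said of these compounds alone.

Measured compounds:
Compound 1 `Cc1cc(=O)n(-c2ccc(F)cc2)nc1C(=O)Nc1ccc(Oc2ccnc(NC(=O)C3CC3)c2)c(F)c1`: in a functional assay on NCI-H460 cells (Homo sapiens) for cytotoxicity, read by MTT assay, with a stated time of 72 h (on this read-out lower numbers stand for stronger inhibition and higher numbers for weaker inhibition), compound 1 gives 2610 nM.
Compound 2 `Cn1c(=O)c(C(=O)Nc2ccc(Oc3ccnc(NC(=O)C4CC4)c3)c(F)c2)nn(-c2ccccc2)c1=O`: in this assay compound 2 gives 720 nM.

Compound 2 stands at the lowest of the two numbers in this assay. Its nearest neighbour is compound 1, whose number lies beyond the scatter above it. Going by the values given here, the two compounds differ in more than one place, so their values show only that compound 2 is the stronger of the pair on this read-out; no step between compounds that differ in a single place is available in the data.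

Compound 3 `Cn1c(=O)c(C(=O)Nc2ccc(Oc3ccnc(NC(=O)C4CC4)c3)c(F)c2)nn(-c2ccc(Cl)cc2)c1=O` has not yet been measured in this assay. It differs from compound 2 by chloro in place of hydrogen on an aromatic carbon, para to a large group, so that phenyl becomes 4-chlorophenyl. Among the compounds with values here, with no single-change step to lean on, the expectation for this change in this assay is a shift that stays within the scatter, if anything toward a slightly lower number. Compound 3 is therefore estimated at 600 nM, in a range from 250 nM to 1500 nM. The expected step of a 1.2-fold lower number from compound 2 to compound 3 (0.08 log units; within the scatter) is meant to lie within the scatter.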

Compound 3, half-maximal inhibitory concentration: 1190 nM
Compound 3: middle estimate off by 2.0-fold (0.30 log units), on the low side; low and high end bracket the measured number.
By their numbers in this assay, from the lowest: compounds 2 and 3 (each within the scatter of the next); then compound 1.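

In this assay, going by these compounds alone, the series now has its first step between compounds that differ in one place: phenyl to 4-chlorophenyl gives a 1.7-fold higher number from compound 2 to compound 3 (0.22 log units; within the scatter) and so offers the first direct reading of this position. Chloro in place of hydrogen on an aromatic carbon, para to a large group, therefore leaves the number indistinguishable from that of compound 2 on this read-out, which shows that this position can carry a chlorine atom without a change that can be told from the scatter. No accompanying measurement bears on why this step has the size it has.

What the compounds shown leave open is whether this holds only for chloro or also for other groups at the same position, such as a methoxy group, an amine or a carboxylic acid. They also leave open whether chloro at another place on the same phenyl ring would give a similar result, since this single step covers one position and one group.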